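The source may report more compounds than this note shows. Statements on the series, on what has been measured and on what is new or still open speak of the compounds shown alone.

Among the measured compounds shown here, compound 1 `CCCCNC(=O)Nc1cccc2c1CN(C)CC2c1ccccc1` is one of two compounds measured in a functional assay on the whole organism for inhibition of sodium-dependent dopamine transporter (Mus musculus); on this read-out lower numbers stand for an effect already at smaller amounts and higher numbers for an effect only at larger amounts of compound. In this assay compound 1 gives 69 mg/kg, the lowest of the two numbers, while its nearest neighbour, compound 2 `CCCCNC(=O)Nc1cccc2c1CN(C)CC2c1ccc(Cl)cc1`, gives about 120 mg/kg. For the measured compounds named here, the only step measured so far, a 1.7-fold higher number from compound 1 to compound 2 (0.24 log units; within the scatter), concerns a chloro in place of hydrogen on an aromatic carbon and lies within the scatter.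

Compound 3 `CN1Cc2c(NC(=O)OCc3ccccc3)cccc2C(c2ccccc2)C1` keeps the shared core of compound 1 and changes it at the carbonyl carbon: benzyloxy in place of butylamino on a carbonyl carbon. Going by the values given here, no measured step touches this part of the molecule; the step from compound 1 to compound 2 alters the aromatic ring, not the group attached to the carbonyl, so it offers no direct guide to the size or direction of the change in this assay. Among the compounds with values here, with the one measured step sitting within the scatter, the expectation for compound 3 is a number near that of compound 1, with a wide range to allow for the untested group. Compound 3 is therefore estimated at 80 mg/kg, within 35 mg/kg to 200 mg/kg, which is an expected step of a 1.2-fold higher number from compound 1 to compound 3 (0.06 log units; within the scatter).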

Compound 3, dose for half-maximal effect: 25 mg/kg
Compound 3: the middle estimate sits 3.2-fold (0.51 log units) above what was measured, outside the stated range (below it).
By their numbers in this assay, from the lowest: compound 3; then compounds 1 and 2 (each within the scatter of the next).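

Among the compounds shown here, the group on the carbonyl carbon proves to count in this assay, something the earlier pair could not show, as its only step lay on the aromatic ring and stayed within the scatter. Here, with benzyloxy in place of butylamino, the result is a 2.8-fold lower number from compound 1 to compound 3 (0.44 log units; beyond the scatter) and so gives the first step in this series that clears the scatter, although a modest one. The change replaces an open chain carrying one hydrogen-bond donor with a group holding a six-membered aromatic ring of carbon only and one hydrogen-bond acceptor, and nothing available explains why the number moves.

The compounds shown leave open which part of this change carries the step, since the ring, the linking oxygen and the loss of the donor all arrive together, and butoxy or benzylamino on the same carbonyl carbon would begin to separate them. They also leave open whether a chloro on the aromatic ring of compound 3 would stay within the scatter, as it does for compound 1.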